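This account rests on a few compounds, and the source may have more. Where it says the series, first, only, none or still open, it means among the compounds named here.

Among the measured compounds shown here, the values measured so far in a functional assay on ASPC1 cells (Homo sapiens) for inhibition, read by MTT assay, with a stated time of 96 h (on this read-out lower numbers stand for stronger inhibition of growth and higher numbers for weaker inhibition of growth), are these.

Compound 1 `O=C(OCc1ccccc1)SCCCCCCNC(=O)c1cc(-c2ccncc2)n[nH]1` gives 32300 nM
Compound 2 `CC(C)C(=O)SCCCCCCNC(=O)c1cc(-c2ccncc2)n[nH]1` gives 31700 nM
Compound 3 `CCCC(=O)SCCCCCCNC(=O)c1cc(-c2ccncc2)n[nH]1` gives 28100 nM

All steps among these three lie within the scatter, so compound 1 stands level with the other two. Compound 4 `CCC(=O)SCCCCCCNC(=O)c1cc(-c2ccncc2)n[nH]1` has not yet been measured. It differs from compound 1 by ethyl in place of benzyloxy on a carbonyl carbon. Two measured steps make the same kind of replacement at that place, one with isopropyl (a 1.0-fold lower number from compound 1 to compound 2 (0.01 log units; within the scatter)) and one with propyl (a 1.1-fold lower number from compound 1 to compound 3 (0.06 log units; within the scatter)). Changing propyl for isopropyl also made little difference (a 1.1-fold lower number from compound 2 to compound 3 (0.05 log units; within the scatter)). For the measured compounds named here, no measured compound carries ethyl there, so this remains an extrapolation, but no step beyond the scatter is expected. The expected change is small (a 1.1-fold lower number from compound 1 to compound 4 (0.05 log units; within the scatter)). For compound 4 the estimated value is 29000 nM in the middle of an expected range from 15000 nM up to 50000 nM at the far end.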

Compound 4, concentration for 50% growth inhibition: > 50000 nM
Compound 4: a limit, no number (the forecaster's own chance of this, stated with the estimate: 5%); middle value at least 1.7-fold (0.23 log units) away from the limit.
By their numbers in this assay, from the lowest: compounds 3, 2 and 1 (each within the scatter of the next). At a limit, above all of these: compound 4.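

Compound 4 gives > 50000 nM in this assay, which is a limit of the assay and not a number. Set against the measured compounds, this reads as an at least 1.5-fold higher number from compound 1 to compound 4 (0.18 log units; that floor lies within the scatter), as an at least 1.5-fold higher number from compound 2 to compound 4 (0.19 log units; that floor lies within the scatter) and as an at least 1.7-fold higher number from compound 3 to compound 4 (0.25 log units; that floor lies within the scatter), so none of these floors on its own establishes a real loss of growth inhibition. What is new is that the level picture shared by the benzyloxy, isopropyl and propyl compounds does not carry over to every group on this carbonyl carbon: the small change of hydrogen in place of methyl on the propyl chain already turns a measured number into a limit.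

On these data alone, how far the true value of compound 4 lies past this limit remains open. Also open, as far as these compounds go, is how a longer chain such as hexanoyl, or an amine, would read at this place.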